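Notes on a chromene sulfonamide pair and an ethyl analogue

The source may report more compounds than this note shows. Statements on the series, on what has been measured and on what is new or still open speak of the compounds shown alone.

Of the compounds shown here, two have been measured in an assay on isolated protein for inhibition of Intestinal-type alkaline phosphatase (Bos taurus), read by spectrophotometry, with stated times of 10 min and 30 min; a higher number here means a weaker inhibitor, a lower number a stronger inhibitor. Compound 1 `CCOC1Oc2ccc(Br)cc2C(=O)/C1=C\Nc1ccc(S(N)(=O)=O)cc1` gives 410 nM in this assay. Compound 2 `CCOC1Oc2ccccc2C(=O)/C1=C\Nc1cccc(S(N)(=O)=O)c1` gives 33500 nM in this assay, the highest of the two numbers; compound 1 differs from compound 2 in more than one place, so the gap between the two values cannot be tied to any single change.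

Compound 3 `CCOC1Oc2ccc(CC)cc2C(=O)/C1=C\Nc1cccc(S(N)(=O)=O)c1` is not yet measured. It differs from compound 2 by ethyl in place of hydrogen on an aromatic carbon of the shared core, with the rest of the molecule unchanged. Among the compounds with values here, no measured pair isolates this change, so the direction is open; the size of the step is expected to be modest either way, and a move toward a lower number is judged somewhat more likely than none.

On that basis compound 3 is expected to give 12000 nM in this assay, within a range from 3000 nM to 45000 nM, which would mean a step of a 2.8-fold lower number from compound 2 to compound 3 (0.45 log units; beyond the scatter).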

Compound 3, inhibition constant: 2100 nM
Compound 3: middle estimate off by 5.7-fold (0.76 log units), on the high side; the measured number lies below the stated range.
By their numbers in this assay, from the lowest: compound 1; then compound 3; then compound 2.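

In this assay, within the data shown here, ethyl in place of hydrogen on an aromatic carbon of the shared core gives a 16-fold lower number from compound 2 to compound 3 (1.20 log units; beyond the scatter) and is the first step that can be tied to a single change. This aromatic carbon is therefore not a silent position: with the rest of the molecule unchanged, a group with no ring, no hydrogen-bond donors or acceptors and no net charge is enough to move the number well beyond the scatter, toward a stronger inhibitor. No measurement available here gives a reason for this step.

Going by these compounds, with a single step at this carbon, it remains open whether the effect grows, holds or falls away with methyl, with a longer chain such as propyl, or with an amine or a carboxylic acid in place of the ethyl. It is also open whether ethyl would give a step of similar size and direction on a compound with the sulfonamide placed as in compound 1, since no pair of compounds shown tests this.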